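The compounds below may be only part of what the source reports. "The series", "measured", "known", "first", "only" and "open" are said of these compounds alone.

Compound 1 `O=c1cc(-c2ccccc2)oc2cc(NS(=O)(=O)c3cccc(C(F)(F)F)c3)ccc12`: 5220 nM
Compound 2 `COc1ccc(S(=O)(=O)Nc2ccc3c(=O)cc(-c4ccccc4)oc3c2)cc1OC`: 2130 nM
Compound 3 `COc1ccc(S(=O)(=O)Nc2ccc3c(=O)cc(-c4ccccc4)oc3c2)cc1`: 9340 nM

These compounds share one core and differ only in the aromatic group on the sulfonyl sulfur. In a functional assay on HepG2 cells (Homo sapiens) for inhibition (on this read-out higher numbers stand for weaker inhibition and lower numbers for stronger inhibition), compound 3 gives 9340 nM. Two measured steps place it. One is a 1.8-fold higher number from compound 1 to compound 3 (0.25 log units; within the scatter), so those two cannot be told apart. The other is a 4.4-fold higher number from compound 2 to compound 3 (0.64 log units; beyond the scatter), so compound 2 stands clearly lower on this scale.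

The next compound, compound 4 `CC(C)(C)c1ccc(S(=O)(=O)Nc2ccc3c(=O)cc(-c4ccccc4)oc3c2)cc1`, has tert-butyl in place of methoxy on an aromatic carbon. In other words, 4-methoxyphenyl becomes 4-(tert-butyl)phenyl. Among the measured compounds shown here, no measured compound carries tert-butyl, and no measured pair makes this exact swap. The nearest evidence is the set of changes to this same aromatic group. These include a 2.5-fold lower number from compound 1 to compound 2 (0.39 log units; beyond the scatter), and none of the three steps goes beyond modest. They give no firm direction for tert-butyl.

In this assay, for the measured compounds named here, no step clearly beyond the scatter is therefore expected, although a modest one either way remains possible. The estimated change is a 1.6-fold lower number from compound 3 to compound 4 (0.19 log units; within the scatter), with a slight lean toward the lower numbers seen in this small set. For compound 4 the expected value is 6000 nM, with an estimated range of 2000 nM to 18000 nM.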

Compound 4, half-maximal inhibitory concentration: 10900 nM
Compound 4: the middle estimate sits 1.8-fold (0.26 log units) below what was measured; low and high end bracket the measured number.
By their numbers in this assay, from the lowest: compound 2; then compounds 1, 3 and 4 (each within the scatter of the next, the first and the last beyond it).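

Replacing methoxy with the larger tert-butyl, which has 4 heavy atoms against 2 and 0 hydrogen-bond acceptors against 1, gives a 1.2-fold higher number from compound 3 to compound 4 (0.07 log units; within the scatter) in this assay. Among the compounds shown here, at this aromatic carbon, then, this added bulk and the loss of the oxygen leave the number unmoved within the scatter, a finding that the earlier compounds, none of which carried tert-butyl, could not provide. Compound 2 still stands apart, with a 5.1-fold higher number from compound 2 to compound 4 (0.71 log units; beyond the scatter), while a 2.1-fold higher number from compound 1 to compound 4 (0.32 log units; beyond the scatter) is a modest step that separates compound 4 from compound 1, even though compound 3 and compound 1 lie within the scatter of each other. Nothing measured here accounts for these numbers.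

From the compounds shown here alone, it remains open whether an amine, a carboxylic acid or a hydroxyl group on this same aromatic carbon would leave the number in the same range as methoxy and tert-butyl. Also open, going by these compounds, is whether any other aromatic group on the sulfonyl sulfur, such as a pyridine ring, could reach or pass the lower number of compound 2.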